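Sulfanyl analogue of compound 1: expected growth inhibition

The source may hold more compounds than are shown below. What is called first, only, known or untested is meant among the compounds shown, and "the series" means these compounds.

Compound 1 `COc1ccc(CNc2nc(SC)nc3ccccc23)cc1` gives 93700 nM in a functional assay on HTB-54 cells (Homo sapiens) for cytotoxicity, read by MTT assay, with a stated time of 72 h (a lower number here means a stronger inhibitor of growth, a higher number a weaker inhibitor of growth), the highest of the three numbers measured; compound 2 `CSc1nc(NCc2ccccc2)c2ccccc2n1` gives 37900 nM and compound 3 `CSc1nc(NCc2ccccc2)c2cccnc2n1` gives 5080 nM. Among the measured compounds shown here, the only step between compounds differing in one place, a 2.5-fold lower number from compound 1 to compound 2 (0.39 log units; beyond the scatter), concerns hydrogen in place of methoxy on an aromatic carbon. Compound 4 `COc1ccc(CNc2nc(S)nc3ccccc23)cc1` differs from compound 1 by hydrogen in place of methyl on a sulfur. For the measured compounds named here, no measured step touches the sulfur or its methyl, so nothing among the three values bears on this change. The expected step of a 1.0-fold lower number from compound 1 to compound 4 (0.02 log units; within the scatter) is therefore none beyond the scatter. Compound 4 is estimated at 90000 nM, within a range from 30000 nM to 280000 nM.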

Compound 4, concentration for 50% growth inhibition: 13500 nM
The estimate for compound 4 lay 6.7-fold (0.82 log units) above the measured number; measured number outside the range, below it.
By their numbers in this assay, from the lowest: compound 3; then compound 4; then compound 2; then compound 1.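

Working at the sulfur, where earlier steps did not reach, a 6.9-fold lower number from compound 1 to compound 4 (0.84 log units; beyond the scatter) in this assay shows that this position matters for growth inhibition. Methylsulfanyl to sulfanyl moves the number beyond the scatter with the methoxy group held in place, so the sulfur substituent cannot be treated as neutral in this series. No measurement at hand accounts for the shift.

On these data alone, whether the same change carries over to compound 2 or compound 3, which lack the methoxy group, remains open. Also open, as far as these compounds go, is how a longer chain on the sulfur, such as ethyl or propyl, or an amine in place of the sulfanyl group would compare.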